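Methoxycarbonyl to a sulfur-bearing chain on the shared core

This account rests on a few compounds, and the source may have more. Where it says the series, first, only, none or still open, it means among the compounds named here.

Two compounds have been run in a functional assay on the whole organism with Rattus norvegicus as the target; on this read-out lower numbers stand for an effect already at smaller amounts and higher numbers for an effect only at larger amounts of compound. Compound 1 `Nc1nc2ccc(CC(F)(F)F)cc2s1` gives 8 mg/kg in this assay. Compound 2 `COC(=O)Cn1c(=N)sc2cc(OC(F)(F)F)ccc21` returns only a limit in this assay, > 10 mg/kg, so where it stands is told only by the limit of > 10 mg/kg in this assay, at which 1 of the 2 values shown sits, and not by a number. Among the compounds with values here, with no number for compound 2, no measured step connects it to compound 1, and the two values show only that one is a number and the other a limit.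

Compound 3 `C[S+]([O-])CCn1c(=N)sc2cc(OC(F)(F)F)ccc21` is the next analogue. It differs from compound 2 as follows: a group of 4 heavy atoms (2 carbon, 1 oxygen, 1 sulfur; no ring) in place of a group of 4 heavy atoms (2 carbon, 2 oxygen; no ring), on a saturated chain carbon bound to an aromatic nitrogen. Within the data shown here, no measured step covers this kind of change, so the size of the step is open. The working expectation for the step is a step that the limit leaves unreadable from compound 2 to compound 3, none beyond the scatter, with a real chance that a limit is returned again. On that basis compound 3 is expected to give about 12 mg/kg in this assay, within 4 mg/kg to 40 mg/kg.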

Compound 3, dose for half-maximal effect: 1.1 mg/kg
Compound 3: middle estimate off by 11-fold (1.04 log units), on the high side; measured number outside the range, below it.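

In this assay, the place on a saturated chain carbon bound to an aromatic nitrogen proves responsive to the group it carries: replacing methoxycarbonyl with the sulfur-bearing group gives an at least 9.0-fold lower number from compound 2 to compound 3 (0.95 log units; beyond the scatter). Both groups count 4 heavy atoms, so heavy-atom count alone does not settle the read-out at this place. The step gives only a minimum size, because one end of it is a limit and not a number: the limit of > 10 mg/kg in this assay, at which 1 of the 3 values shown sits.

Which part of the entering group goes with the step stays open: a methyl thioether, a methyl sulfone, a longer chain, an amine or a carboxylic acid at this place would begin to separate these possibilities. Also open, from the compounds shown here alone, is whether the step holds with a group other than trifluoromethoxy on the shared core.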